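Replacing the Side Chain of Compound 3

This account rests on a few compounds, and the source may have more. Where it says the series, first, only, none or still open, it means among the compounds named here.

In an ADME assay on BJ cells (Homo sapiens) for cytotoxicity, with a stated time of 72 h (on this read-out higher numbers stand for an effect only at larger amounts of compound and lower numbers for an effect already at smaller amounts), compound 3 (`CCN(CC)C(=O)COc1cc2c(-n3nc(-c4ccccn4)nc3N)ncnc2cc1OC`) gives > 25000 nM as a limit, not a number. Compound 1 (`COc1cc2ncnc(-n3nc(-c4ccccn4)nc3N)c2cc1[N+](=O)[O-]`) gives > 13000 nM as a limit too. Compound 2 (`CCOC(=O)CNc1nc(-n2nc(-c3ccccn3)nc2N)c2cc(OC)c(OC)cc2n1`) likewise gives > 27000 nM as a limit. Compound 3 therefore stands among limits only, with no exact value on either side. Compound 4 (`COc1cc2ncnc(-n3nc(-c4ccccn4)nc3N)c2cc1OCCCNC(=O)OCC(F)(F)F`) has 2-(((2,2,2-trifluoroethoxy)carbonyl)amino)ethyl in place of diethylcarbamoyl on a saturated chain carbon bound to an oxygen on an aromatic ring. Among the measured compounds shown here, the one measured step that bears on this is a step that the two limits leave unreadable from compound 1 to compound 3 and it gives no size to carry over. The estimated step is a number no higher from compound 3 to compound 4 (the limit leaves the size open) and nothing beyond the scatter is expected in this assay in either direction. For compound 4 the estimate is 25000 nM within an expected range of 10000 nM to 50000 nM and another limit is likely.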

Compound 4, half-maximal effective concentration: > 11000 nM
Compound 4 ended at the assay's limit; the forecaster's own chance of this, stated with the estimate: 75%; the middle value does not contradict the limit.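

Compound 3 and compound 4 each give only a limit, not a number, and the step between them cannot be read. The compounds shown leave open at what amount any of them would harm these cells.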